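Swapping Fluorines on the Sulfonyl Aryl Group

The compounds below may be only part of what the source reports. "The series", "measured", "known", "first", "only" and "open" are said of these compounds alone.

Compound 2 `COCC1CCN(c2c(S(=O)(=O)c3cc(F)cc(F)c3)cnc3cc(F)ccc23)CC1` and compound 1 `COCC1CCN(c2c(S(=O)(=O)c3ccc(F)cc3)cnc3cc(F)ccc23)CC1` share one core and differ only in the ring on the sulfonyl sulfur. In an assay on isolated protein for displacement of a labelled ligand from metabotropic glutamate receptor 5 (Homo sapiens), with a stated time of 60 min, tested at 1 uM (a lower number here means less inhibition, a higher number more inhibition at the concentration tested (going by the name of the read-out)), compound 2 gives 83% and compound 1 gives 76.1%; the change 4-fluorophenyl in place of 3,5-difluorophenyl on a sulfonyl sulfur made a step of a number 6.9 percentage points lower from compound 2 to compound 1 (within the scatter). Compound 3 `COc1ccc2ncc(S(=O)(=O)c3cc(F)cc(F)c3)c(N3CCC(C)CC3)c2c1` is built on another core; how its core differs from that of compound 2 is not broken down here. In this assay compound 3 gives 30%, the lowest of the three numbers. Compound 4 `COc1ccc2ncc(S(=O)(=O)c3ccc(F)cc3)c(N3CCC(C)CC3)c2c1` carries the same change as compound 1, now on the core of compound 3: 4-fluorophenyl in place of 3,5-difluorophenyl on a sulfonyl sulfur. Because the step of a number 6.9 percentage points lower from compound 2 to compound 1 (within the scatter) stayed within the scatter, a similarly small step is expected from compound 3 to compound 4, namely a number 5 percentage points lower from compound 3 to compound 4 (within the scatter). Compound 4 is therefore estimated at 25%, between 8% and 42%.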

Compound 4, a percentage reported as inhibition, at one concentration (the size of the read-out at that concentration, not a potency): 27%
For compound 4 the middle estimate is 2 percentage points below the measured one; the range from low to high includes it.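

In this assay, 4-fluorophenyl in place of 3,5-difluorophenyl on a sulfonyl sulfur gave a number 3 percentage points lower from compound 3 to compound 4 (within the scatter) and so left the two compounds of this pair indistinguishable. The same holds on both cores, and the two steps agree: the same change on two cores in this assay, a number 6.9 percentage points lower (within the scatter) from compound 2 to compound 1 and a number 3 percentage points lower (within the scatter) from compound 3 to compound 4, 3.9 percentage points apart, within the scatter of two such steps. Going by these compounds alone, this shows that the change carried over between these two cores without a visible effect, but with only two pairs tested at a single concentration, it does not show that the change would behave alike on any other core.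

The compounds shown leave open what other groups on the sulfonyl sulfur would do, such as an unsubstituted phenyl, a 4-methoxyphenyl or a 4-aminophenyl. From the compounds shown here alone, whether any such replacement would produce a step beyond the scatter, and whether that step would then carry between cores, also remains open.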